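Taking the Fluorine Off the Ring of Compound 3

The compounds below may be only part of what the source reports. "The series", "measured", "known", "first", "only" and "open" are said of these compounds alone.

Of the compounds shown here, three sharing a core have been tested in an ADME assay on 184B5 cells (Homo sapiens) for cytotoxicity, read by MTT assay, with a stated time of 72 h; a lower number here means a stronger inhibitor of growth, a higher number a weaker inhibitor of growth. Compound 1 `COc1ccc(OC(=O)Nc2ccc([Se]C#N)cc2)cc1` gives 4500 nM. Compound 2 `CCCCCCOC(=O)Nc1ccc([Se]C#N)cc1` gives 4600 nM. Compound 3 `N#C[Se]c1ccc(NC(=O)Oc2ccc(F)cc2)cc1` gives 6900 nM, the largest of the three numbers, yet its gaps to compound 2 and to compound 1 both lie within the scatter, so on these data the three cannot be told apart.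

Compound 4 `N#C[Se]c1ccc(NC(=O)Oc2ccccc2)cc1` differs from compound 3 by hydrogen in place of fluoro on an aromatic carbon. Among the compounds with values here, the only measured step that bears on this, a 1.5-fold higher number from compound 1 to compound 3 (0.19 log units; within the scatter), exchanged one small group for another at that same carbon and moved nothing beyond the scatter. Removing the fluoro is therefore expected to leave the number essentially unchanged, a step of a 1.3-fold lower number from compound 3 to compound 4 (0.10 log units; within the scatter). Compound 4 is estimated at 5500 nM, with a range from 2500 nM to 12000 nM.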

Compound 4, concentration for 50% growth inhibition: 400 nM
The estimate for compound 4 lay 14-fold (1.14 log units) above the measured number, and the stated range ends above it.
By their numbers in this assay, from the lowest: compound 4; then compounds 1, 2 and 3 (each within the scatter of the next).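

Within the data shown here, at this position the group matters far more than the earlier compounds suggested in this assay: removing fluoro gives a 17-fold lower number from compound 3 to compound 4 (1.24 log units; beyond the scatter) and removing methoxy gives an 11-fold lower number from compound 1 to compound 4 (1.05 log units; beyond the scatter) even though exchanging those two groups for each other moved nothing beyond the scatter. Compound 4 is the strongest inhibitor of growth of the four, and replacing hexyl with phenyl on the oxygen next to the carbonyl group gives a 12-fold lower number from compound 2 to compound 4 (1.06 log units; beyond the scatter) as well. Going by these compounds, whether a chlorine atom or an amine at that carbon would keep the lower number remains open. Nothing available explains why hydrogen stands apart from both fluoro and methoxy here.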